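The source may report more compounds than this note shows. Statements on the series, on what has been measured and on what is new or still open speak of the compounds shown alone.

Three compounds share one core: compound 1 `O=S(=O)(/C=C/c1ccc(O)c(O)c1)CCC1CCCCC1`, compound 2 `O=S(=O)(/C=C/c1ccc(O)c(O)c1)CC1CCCCC1` and compound 3 `CC(C)(C)OC(=O)N1CCCC1CS(=O)(=O)/C=C/c1ccc(O)c(O)c1`. In a functional assay, read by fluorescence and spectrophotometry, with a stated time of 1 h (on this read-out higher numbers stand for an effect only at larger amounts of compound and lower numbers for an effect already at smaller amounts), compound 1 gives 9800 nM, compound 2 gives 7500 nM and compound 3 gives 7100 nM; all three numbers fall within the usual scatter of one another, so none of them can be told apart on this evidence.

Compound 4 `O=S(=O)(/C=C/c1ccc(O)c(O)c1)CCCc1ccccc1` has not yet been measured. It differs from compound 1 in one place: benzyl in place of cyclohexyl on a saturated chain carbon, two bonds along the chain from a sulfonyl sulfur. Within the data shown here, the only measured step that bears on this change is a 1.3-fold lower number from compound 1 to compound 2 (0.12 log units; within the scatter), which also swaps one saturated ring group for another on the same part of the chain and leaves the number essentially where it was. Among the measured compounds shown here, a switch from a saturated to an aromatic six-membered ring carries no measured precedent here, and the shared core is untouched. The expectation is therefore a step of a 1.2-fold lower number from compound 1 to compound 4 (0.09 log units; within the scatter) in this assay, with no movement beyond the scatter. Compound 4 is estimated at 8000 nM, expected to lie between 3000 nM and 25000 nM.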

Compound 4, half-maximal effective concentration: 11500 nM
The estimate for compound 4 lay 1.4-fold (0.16 log units) below the measured number; low and high end bracket the measured number.
By their numbers in this assay, from the lowest: compounds 3, 2, 1 and 4 (each within the scatter of the next).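

Putting benzyl in place of cyclohexyl on a saturated chain carbon, two bonds along the chain from a sulfonyl sulfur, gives a 1.2-fold higher number from compound 1 to compound 4 (0.07 log units; within the scatter) in this assay. Compounds 1 and 2 carried only a six-membered non-aromatic ring of carbon on this part of the chain, so compound 4 adds the first case of a six-membered aromatic ring, and that swap leaves no difference that can be told apart from the usual scatter. No supporting measurement bears on this result.

Ranked by their numbers, the four compounds stand each within the scatter of the next, so none of them yet shows a change at this position that moves the number beyond the scatter. From the compounds shown here alone, whether an amine, a carboxylic acid or a longer chain at this place would do so remains open.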